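This account rests on a few compounds, and the source may have more. Where it says the series, first, only, none or still open, it means among the compounds named here.

Measured so far:
compound 1 `Nc1cc(N)c2nc(-c3ccccc3)c(NCc3ccc(Cl)c(Cl)c3)nc2c1` — < 100000 nM
compound 2 `COc1ccc(CNc2nc3cc(N)cc(N)c3nc2-c2ccccc2)cc1OC` — < 100000 nM

In a functional assay on SW-620 cells (Homo sapiens) for inhibition, read by sulforhodamine B assay, with a stated time of 48 h (a higher number here means that more compound is tolerated, a lower number that less compound is tolerated), compound 1 gives < 100000 nM, which is a limit of the assay and not a number. In this assay compound 2 likewise gives < 100000 nM, again a limit rather than a number. Compound 2 therefore stands only at a limit, with no measured value to place it against. Among the compounds with values here, the one step between measured compounds, a step that the two limits leave unreadable from compound 1 to compound 2, cannot be read in size because of the limit of < 100000 nM in this assay, at which 2 of the 2 values shown sit.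

Compound 3 `COc1cc(CNc2nc3cc(N)cc(N)c3nc2-c2ccccc2)cc(OC)c1OC` differs from compound 2 by methoxy in place of hydrogen on an aromatic carbon. Within the data shown here, no measured step bears on this change; the single step known is unreadable, so no direction or size can be drawn from it. Compound 3 is expected at 50000 nM, with a range of 10000 nM to 100000 nM, most likely again a limit. The step from compound 2 to compound 3 is expected to be a step that the limit leaves unreadable from compound 2 to compound 3, nothing beyond the scatter.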

Compound 3, concentration lethal to 50% of the cells: < 50200 nM
Compound 3: no number, only a limit; the forecaster's own chance of this, stated with the estimate: 70%; the middle value does not contradict the limit.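

In this assay compound 3 gives < 50200 nM, a limit and not a number. Compound 2 gives < 100000 nM, also a limit, so no step can be read between compound 2 and compound 3. The compounds shown leave open whether methoxy in place of hydrogen shifts the read-out at all.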